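Isatin and oxindole triazoles: configuration at the ring carbon

The source may report more compounds than this note shows. Statements on the series, on what has been measured and on what is new or still open speak of the compounds shown alone.

Measured compounds:
compound 1 `O=C1C(=O)N(Cc2cn(Cc3ccccc3)nn2)c2ccccc21`: 54700 nM
compound 2 `CC(C)[C@@H]1CC[C@@H](C)C[C@@H]1n1cc(CN2C(=O)C(=O)c3ccccc32)nn1`: 53800 nM
compound 3 `O=C1N(Cc2cn(Cc3ccccc3)nn2)c2ccccc2[C@@]1(O)c1ccsc1`: 98000 nM

All three were tested in a functional assay on A549 cells (Homo sapiens) for inhibition, read by MTT assay, with a stated time of 72 h; on this read-out lower numbers stand for stronger inhibition and higher numbers for weaker inhibition. Compound 3 has the highest number of the three; its nearest neighbour is compound 1, and the gap to compound 2 is of the same order. Both gaps are within the scatter of repeated measurements, so no order among compounds 1, 2 and 3 can be stated, and none of them can be called weaker or stronger than the others.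

Compound 4 `O=C1N(Cc2cn(Cc3ccccc3)nn2)c2ccccc2[C@]1(O)c1ccsc1` is not yet measured. Relative to compound 3 the change is the two compounds have the same atoms and bonds and differ only in configuration as drawn: 1 of 1 stereo elements differ; a stereocentre at a saturated ring carbon is drawn R in compound 3 and S in compound 4. Among the compounds with values here, no measured pair in the set differs only in configuration at this centre, so the size of a step of this kind is unknown here; the expectation is a step of no more than the scatter in either direction, with a wider range allowed for the untested case. The estimate for compound 4 in this assay is 90000 nM, with a range from 35000 nM to 250000 nM. This means the expected step from compound 3 to compound 4 is a 1.1-fold lower number from compound 3 to compound 4 (0.04 log units; within the scatter).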

Compound 4, half-maximal inhibitory concentration: > 100000 nM
Compound 4 gave a limit, no number; the forecaster's own chance of this, stated with the estimate: 25%; middle value at least 1.1-fold (0.04 log units) away from the limit.
By their numbers in this assay, from the lowest: compounds 2, 1 and 3 (each within the scatter of the next). At a limit, above all of these: compound 4.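

In this assay compound 4 gives > 100000 nM, which is a limit of the assay and not a number. Within the data shown here, this is the first pair that isolates configuration at the saturated ring carbon, and it can be read only as a floor: an at least 1.0-fold higher number from compound 3 to compound 4 (0.00 log units; that floor lies within the scatter), so the change from R to S shows no difference that can be told from the scatter. Any true gap between these two compounds could be traced to configuration alone: the fact that compounds 3 and 4 differ only in the configuration as drawn

From the compounds shown here alone, the real size of this step stays open, and a single pair cannot show whether configuration at this centre matters elsewhere. Also open, going by these compounds, is how an amine or a carboxylic acid in place of the hydroxyl at the saturated ring carbon would read in this assay, in either configuration.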